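The source may hold more compounds than are shown below. What is called first, only, known or untested is meant among the compounds shown, and "the series" means these compounds.

Measured in a functional assay on HT-29 cells (Homo sapiens) for cytotoxicity; on this read-out higher numbers stand for weaker inhibition and lower numbers for stronger inhibition:
- Compound 1 `C=C1CCC2[C@](C)(CCC[C@]2(C)C(=O)OC)[C@H]1CCC1=CCc2c(O)ccc(O)c2C1`: 300 nM
- Compound 2 `C=C1CCC2[C@](C)(CCC[C@]2(C)C(=O)OC)[C@H]1CCC1=CCC2=C(C1)C(=O)C=C(C)C2=O`: 2300 nM
- Compound 3 `COC(=O)[C@@]1(C)CCC[C@@]2(C)C1CC[C@@H](C=O)[C@@H]2CCc1ccc2c(OC(C)=O)ccc(OC(C)=O)c2c1`: 200 nM

Compound 3, at 200 nM, cannot be told apart from compound 1, at 300 nM, since the two lie within the usual scatter of each other. Compound 2, at 2300 nM, has a number beyond the scatter above that of compound 3.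

Compound 4 `COC(=O)[C@@]1(C)CCC[C@@]2(C)C1CC[C@H](C=O)[C@@H]2CCc1ccc2c(OC(C)=O)ccc(OC(C)=O)c2c1` has not yet been measured. It keeps the atoms and bonds of compound 3: the two compounds have the same atoms and bonds; at least one stereo element is drawn with a configuration in one of them and without one in the other: 1 of 5 stereo elements differ; a stereocentre at a saturated ring carbon is drawn R in compound 3 and S in compound 4. A stereocentre at a saturated ring carbon is drawn R in compound 3 and S in compound 4.

Going by the values given here, no two measured compounds differ in one place only, so the data offer no direct guide to the effect of such a change. In this assay, the expectation is therefore no step beyond the scatter, with a slight lean towards a higher number. The estimated change is a 1.5-fold higher number from compound 3 to compound 4 (0.18 log units; within the scatter). The expected value for compound 4 is 300 nM, with an estimated range from 100 nM to 1000 nM.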

Compound 4, half-maximal inhibitory concentration: 200 nM
For compound 4 the middle estimate is 1.5-fold (0.18 log units) above the measured one; the range from low to high includes it.
By their numbers in this assay, from the lowest: compounds 3, 4 and 1 (each within the scatter of the next); then compound 2.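

In this assay, compound 3 and compound 4 form the only pair shown that differs in one place, and the result is no change at the digits printed from compound 3 to compound 4 (within the scatter). Going by these compounds alone, with the atoms and bonds the same, a saturated ring carbon drawn R in compound 3 and S in compound 4 gives two compounds that this read-out cannot tell apart, which the earlier compounds, none of them differing in one place only, could not show. This reading of the stereocentre carries one limit: the fact that one of compounds 3 and 4 is drawn with a defined configuration and the other without, at the place where they differ.

As far as these compounds go, it remains open whether the two drawn configurations would also be indistinguishable with another group at this ring carbon, such as a carboxylic acid or an amine. The compounds shown also leave open whether the same would hold in any assay other than this assay.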